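A few compounds are considered here, and "the series" means these few. Any claim that something is new, unique, unknown or untested is made for them only; others in the source may bear on it.

In an assay on isolated protein for inhibition of Amine oxidase [flavin-containing] A (Homo sapiens), read by fluorescence, with a stated time of 30 min (a lower number here means a stronger inhibitor, a higher number a weaker inhibitor), compound 1 `COc1cc2sn(CCCN(C)Cc3ccccc3)c(=O)c2cc1OC` gives 6900 nM, and compound 2 `CCN(CCCn1sc2cc(OC)c(OC)cc2c1=O)Cc1ccccc1` gives 9900 nM; the two numbers lie within the scatter of each other, and the step of a 1.4-fold higher number from compound 1 to compound 2 (0.16 log units; within the scatter) concerns only the saturated chain carbon bound to the amine nitrogen. Compound 3 `COc1ccccc1CN(C)CCCn1sc2cc(OC)c(OC)cc2c1=O` differs from compound 1 by methoxy in place of hydrogen on an aromatic carbon, a change on the benzyl ring rather than at the amine. Going by the values given here, no measured step touches that ring, so nothing beyond the scatter is assumed. Compound 3 is therefore expected to give 6900 nM (range 2500 nM to 19000 nM), an expected step of no change at the digits printed from compound 1 to compound 3 (within the scatter).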

Compound 3, half-maximal inhibitory concentration: 9400 nM
The estimate for compound 3 lay 1.4-fold (0.13 log units) below the measured number; the range from low to high includes it.
By their numbers in this assay, from the lowest: compounds 1, 3 and 2 (each within the scatter of the next).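

Going by these compounds alone, on the benzyl ring, methoxy in place of hydrogen on an aromatic carbon, ortho to a large group, gives in this assay a 1.4-fold higher number from compound 1 to compound 3 (0.13 log units; within the scatter), the only reading at this ring. So 2-methoxybenzyl and benzyl cannot be told apart here, just as the two amine substituents of compound 1 and compound 2 could not. Nothing available bears on the reason for this result.

Still open, as far as these compounds go, is whether a larger change at this ring carbon, such as a chlorine or a hydroxyl, would move the number beyond the scatter. Also open, from the compounds shown here alone, is the effect of a longer chain between the amine and the shared core.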